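Removing a methoxy group from a urea-linked aryl in compound 4

The source may report more compounds than this note shows. Statements on the series, on what has been measured and on what is new or still open speak of the compounds shown alone.

Measured compounds in a functional assay on PC-3 cells (Homo sapiens) for inhibition, with a stated time of 72 h; on this read-out higher numbers stand for weaker inhibition and lower numbers for stronger inhibition:
compound 1 `Cc1ccc(NC(=O)Nc2nc(Nc3ccccc3)cc(Sc3c[nH]c4ccccc34)n2)cc1`: 18500 nM
compound 2 `COc1ccc(NC(=O)Nc2nc(Sc3c[nH]c4ccccc34)cc(N3CCN(Cc4ccccc4)CC3)n2)cc1`: 16700 nM
compound 3 `Cc1cc(Cl)ccc1NC(=O)Nc1nc(NC2CC2)cc(Sc2c[nH]c3ccccc23)n1`: 11100 nM

All three measured compounds share a core carrying the urea and the indolylthio group, and in this assay their numbers lie close together. Compound 2 gives 16700 nM, and neither compound 1 nor compound 3 is separated from it by more than the usual scatter of repeated measurements, so no ordering among the three can be read from these values.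

Compound 4 `O=C(Nc1ccccc1)Nc1nc(Sc2c[nH]c3ccccc23)cc(N2CCN(Cc3ccccc3)CC2)n1` is compound 2 with one alteration: hydrogen in place of methoxy on an aromatic carbon. Among the measured compounds shown here, no pair of measured compounds differs in exactly one place, so there is no measured step to draw on for this kind of change. The three compounds differ from one another in several places at once and still give similar numbers, which suggests that this small change is unlikely to move the result far. The step from compound 2 to compound 4 is expected to be a 1.1-fold higher number from compound 2 to compound 4 (0.03 log units; within the scatter), within the scatter. Compound 4 is therefore estimated at 18000 nM, with a range from 9000 nM to 36000 nM, because compound 2 gives 16700 nM and the measured set shows little spread.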

Compound 4, half-maximal inhibitory concentration: 42500 nM
Compound 4: the middle estimate sits 2.4-fold (0.37 log units) below what was measured; measured number above the stated range.
By their numbers in this assay, from the lowest: compounds 3, 2 and 1 (each within the scatter of the next); then compound 4.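

In this assay, among the compounds shown here, hydrogen in place of methoxy gives a 2.5-fold higher number from compound 2 to compound 4 (0.41 log units; beyond the scatter), the first change at a single place and one that lies beyond the scatter. For the compounds shown here, the 4-methoxyphenyl to phenyl change therefore weakens inhibition modestly, which the earlier compounds could not show, since they differ from one another in several places at once. Nothing available explains why this methoxy group matters.

From the compounds shown here alone, it remains open whether the effect depends on the methoxy group in particular or would also appear with another group on that aromatic carbon, such as a hydroxyl, an ethoxy or a fluorine. This single step also cannot show whether the same change would have a similar effect in compounds that differ from compound 2 elsewhere.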